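The source may hold more compounds than are shown below. What is called first, only, known or untested is meant among the compounds shown, and "the series" means these compounds.

Measured compounds in a functional assay on cells for inhibition, with Murine T-cell line (Mus musculus) as the target; a higher number here means a weaker inhibitor, a lower number a stronger inhibitor:

- compound 1 `CC[C@@H]1/C=C(\C)C[C@H](C)C[C@H](OC)[C@H]2O[C@@](O)(C(=O)C(=O)N3CCCC[C@H]3C(=O)O[C@H](/C(C)=C/[C@@H]3CC[C@@H](Oc4ccc(O)cc4)[C@H](OC)C3)[C@H](C)[C@@H](O)CC1=O)[C@H](C)C[C@@H]2OC`: 0.8 nM
- compound 2 `CC[C@@H]1/C=C(\C)C[C@H](C)C[C@H](OC)[C@H]2O[C@@](O)(C(=O)C(=O)N3CCCC[C@H]3C(=O)O[C@H](/C(C)=C/[C@@H]3CC[C@@H](Oc4ccc(F)cc4)[C@H](OC)C3)[C@H](C)[C@@H](O)CC1=O)[C@H](C)C[C@@H]2OC`: 3.4 nM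
- compound 3 `CC[C@@H]1/C=C(\C)C[C@H](C)C[C@H](OC)[C@H]2O[C@@](O)(C(=O)C(=O)N3CCCC[C@H]3C(=O)O[C@H](/C(C)=C/[C@@H]3CC[C@@H](Oc4cccc(O)c4)[C@H](OC)C3)[C@H](C)[C@@H](O)CC1=O)[C@H](C)C[C@@H]2OC`: 1.7 nM

Compound 3 gives the second highest number of the three. Its nearest neighbour is compound 2, with a 2.0-fold lower number from compound 2 to compound 3 (0.30 log units; within the scatter), a gap that is within the scatter, so no order between compound 2 and compound 3 can be read from these two values. Compound 1 stands lower, with a 2.1-fold higher number from compound 1 to compound 3 (0.33 log units; beyond the scatter), a gap that is beyond the scatter.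

Compound 4 `CC[C@@H]1/C=C(\C)C[C@H](C)C[C@H](OC)[C@H]2O[C@@](O)(C(=O)C(=O)N3CCCC[C@H]3C(=O)O[C@H](/C(C)=C/[C@@H]3CC[C@@H](Oc4ccc(N(C)C)cc4)[C@H](OC)C3)[C@H](C)[C@@H](O)CC1=O)[C@H](C)C[C@@H]2OC` differs from compound 3 in one place: 4-(dimethylamino)phenyl in place of 3-hydroxyphenyl on an oxygen on a saturated carbon. Among the measured compounds shown here, the only measured step that alters the group on this aryl ether is a 4.3-fold higher number from compound 1 to compound 2 (0.63 log units; beyond the scatter), where the hydroxy donor is lost and the number rises modestly. Compound 4 likewise loses the single hydrogen-bond donor and carries a larger group in the 4-position of the ring, the position that in compound 1 and compound 2 gave the spread between them. Compound 2 and compound 3, both without a 4-hydroxy group, sit within the scatter of each other. On this basis a small rise, close to or just beyond the scatter, is expected for a 1.9-fold higher number from compound 3 to compound 4 (0.27 log units; within the scatter). For compound 4 in this assay the expected value is 3.2 nM, with a range from 1.2 nM to 9 nM.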

Compound 4, half-maximal inhibitory concentration: 1.1 nM
Compound 4: middle estimate off by 2.9-fold (0.46 log units), on the high side; the whole stated range lies above it.
By their numbers in this assay, from the lowest: compounds 1, 4, 3 and 2 (each within the scatter of the next, the first and the last beyond it).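

In this assay, the 4-(dimethylamino)phenyl group, with 0 hydrogen-bond donors, gives no separation from the hydroxyphenyl groups, with a 1.4-fold higher number from compound 1 to compound 4 (0.14 log units; within the scatter) and a 1.5-fold lower number from compound 3 to compound 4 (0.19 log units; within the scatter), so a hydrogen-bond donor on this ring is not required for a number at this level. The fluoro group in compound 2 is now the one that stands apart at this ring carbon: a 3.1-fold lower number from compound 2 to compound 4 (0.49 log units; beyond the scatter), a step beyond the scatter, shows that the earlier step, a 4.3-fold higher number from compound 1 to compound 2 (0.63 log units; beyond the scatter), cannot be read as a general cost of losing the hydroxy group, since compound 4 lacks that group too. No measurement here explains why dimethylamino and hydroxy give numbers within the scatter of each other while fluoro does not.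

The compounds shown leave open whether a primary amine, a methoxy group or a bare phenyl ring on this oxygen would group with compound 1 and compound 4 or with compound 2. From the compounds shown here alone, it also remains open whether a 3-(dimethylamino)phenyl group or a longer chain on the nitrogen would keep a number at this level.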